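A Chlorine-Bearing Swap on Compound 2

The compounds below may be only part of what the source reports. "The series", "measured", "known", "first", "only" and "open" are said of these compounds alone.

For the measured compounds named here, in a functional assay on HT-29 cells (Homo sapiens) for cytotoxicity, read by MTT assay, with a stated time of 72 h (a lower number here means a stronger inhibitor, a higher number a weaker inhibitor), compound 2 (`O=C(CN1CCN(c2nnc(Cc3ccncc3)c3ccccc23)CC1)Nc1ccc(F)c(F)c1`) gives 2320 nM, the higher of the two numbers so far, and compound 1 (`O=C(CN1CCN(c2nnc(Cc3ccncc3)c3ccccc23)CC1)Nc1ccc(F)c(Cl)c1`) gives 880 nM. Compound 3 (`Cc1cccc(Cl)c1NC(=O)CN1CCN(c2nnc(Cc3ccncc3)c3ccccc23)CC1`) differs from compound 2 on the amide-type nitrogen: 2-chloro-6-methylphenyl in place of 3,4-difluorophenyl on an amide-type nitrogen. Going by the values given here, one measured step bears on this: a 2.6-fold higher number from compound 1 to compound 2 (0.42 log units; beyond the scatter), a modest change with fluoro in place of chloro. Among the compounds with values here, no measured compound carries the 2-chloro-6-methylphenyl group, so only a small move towards a lower number is expected, perhaps none beyond the scatter. The expected change is a 1.8-fold lower number from compound 2 to compound 3 (0.25 log units; within the scatter). Compound 3 is estimated at 1300 nM, within a range of 450 nM to 4000 nM.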

Compound 3, half-maximal inhibitory concentration: 22600 nM
Compound 3: the middle estimate sits 17-fold (1.24 log units) below what was measured; the whole stated range lies below it.
By their numbers in this assay, from the lowest: compound 1; then compound 2; then compound 3.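

In this assay swapping the whole aryl group on the amide-type nitrogen gives a 9.7-fold higher number from compound 2 to compound 3 (0.99 log units; beyond the scatter) and a 26-fold higher number from compound 1 to compound 3 (1.41 log units; beyond the scatter) as well, so 2-chloro-6-methylphenyl gives a higher number than either halogenated partner. For the compounds shown here, this position therefore responds more strongly than the single fluoro-for-chloro change suggested. Nothing measured here explains the jump.

The compounds shown leave open whether the chloro group, the methyl group or their combination accounts for the change. A 2-chlorophenyl or 2-methylphenyl group would separate them, while a methoxy group or an amine on the ring would test other substituents.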